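The source may hold more compounds than are shown below. What is called first, only, known or untested is meant among the compounds shown, and "the series" means these compounds.

Working notes on the series. Compound 1, `CS(=O)(=O)OC1CCC(CN2CCN(c3cc(=O)c4cc(C(F)(F)F)cc([N+](=O)[O-])c4s3)CC2)CC1`, is tested in an ADME assay on Vero cells (Chlorocebus sabaeus) for cytotoxicity, read by MTT assay, with a stated time of 48 h; a higher number here means a weaker inhibitor, a lower number a stronger inhibitor. In this assay compound 1 gives only a limit, > 64 ug/mL. Compound 2, `O=C(OC1CCC(CN2CCN(c3cc(=O)c4cc(C(F)(F)F)cc([N+](=O)[O-])c4s3)CC2)CC1)C1CCC1`, likewise gives only a limit in this assay, > 64 ug/mL. Compound 3, `O=C(NC1CCC(CN2CCN(c3cc(=O)c4cc(C(F)(F)F)cc([N+](=O)[O-])c4s3)CC2)CC1)c1ccccc1`, gives in this assay 44.3 ug/mL. The measured steps are a step that the two limits leave unreadable from compound 1 to compound 2, an at least 1.4-fold lower number from compound 1 to compound 3 (0.15 log units; that floor lies within the scatter) and an at least 1.4-fold lower number from compound 2 to compound 3 (0.15 log units; that floor lies within the scatter); the two limits the limit of > 64 ug/mL in this assay, at which 2 of the 3 values shown sit, leave the size of the first unreadable, and the other two rest on floors within the scatter. Compound 4, `COc1ccc(C(=O)OC2CCC(CN3CCN(c4cc(=O)c5cc(C(F)(F)F)cc([N+](=O)[O-])c5s4)CC3)CC2)cc1`, differs from compound 1 by (4-methoxyphenyl)carbonyl in place of methylsulfonyl on an oxygen on a saturated carbon. Both esters so far sit at the limit, so for compound 4 the step of a number no higher from compound 1 to compound 4 (the limit leaves the size open) is expected to stay within the scatter. Compound 4 is therefore estimated at 64 ug/mL, between 35 ug/mL and 130 ug/mL.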

Compound 4, half-maximal inhibitory concentration: > 64 ug/mL
Compound 4 was reported as a limit; the forecaster's own chance of this, stated with the estimate: 60%; the middle value sits exactly at the limit.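

On the oxygen on a saturated carbon, (4-methoxyphenyl)carbonyl, with its aromatic ring, leaves this assay at the same limit as methylsulfonyl and cyclobutylcarbonyl: the limit of > 64 ug/mL in this assay, at which 3 of the 4 values shown sit. The steps among compound 1, compound 2 and compound 4 cannot be read. Among these compounds, the one readable new step is an at least 1.4-fold higher number from compound 3 to compound 4 (0.15 log units; that floor lies within the scatter), so a second ester still gives no gap from the benzamido group beyond the scatter.

As far as these compounds go, it remains open whether any group at this place moves the number clearly. A free amine or a carboxylic acid on the saturated ring carbon would test that.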